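The compounds below may be only part of what the source reports. "The series", "measured", "known", "first", "only" and "open" are said of these compounds alone.

Compound 1 `CS(=O)(=O)N1CCC2(CC1)OOC1(CCCC1)OO2`: > 100 ug/mL (a limit)
Compound 2 `O=S(=O)(CCCCl)N1CCC2(CC1)OOC1(CCCC1)OO2`: > 100 ug/mL (a limit)
Compound 3 `O=S(=O)(Cc1ccccc1)N1CCC2(CC1)OOC1(CCCC1)OO2`: > 100 ug/mL (a limit)

In a functional assay on Huh-7 cells (Homo sapiens) for cytotoxicity, read by MTT assay, with a stated time of 72 h (on this read-out lower numbers stand for higher toxicity in this test and higher numbers for lower toxicity in this test), compound 3 has no number, only the limit > 100 ug/mL. Compound 4 `Cc1ccc(S(=O)(=O)N2CCC3(CC2)OOC2(CCCC2)OO3)cc1` carries 4-methylphenyl in place of benzyl on a sulfonyl sulfur. The measured steps give no size to work from: a step that the two limits leave unreadable from compound 1 to compound 3, a step that the two limits leave unreadable from compound 2 to compound 3 and a step that the two limits leave unreadable from compound 1 to compound 2. The series shows only (the limit of > 100 ug/mL in this assay, at which 3 of the 3 values shown sit). Among the compounds with values here, none of the measured steps puts 4-methylphenyl on a sulfonyl sulfur, so the expectation rests on that shared limit alone. No step beyond the scatter is expected in this assay, and the estimated change is a step that the limit leaves unreadable from compound 3 to compound 4. For compound 4 the estimated value is 130 ug/mL, with an expected range from 60 ug/mL to 250 ug/mL.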

Compound 4, half-maximal cytotoxic concentration: > 100 ug/mL
Compound 4 was reported as a limit; the forecaster's own chance of this, stated with the estimate: 75%; the middle value lies beyond the limit too.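

Within the data shown here, no step among compound 1, compound 2, compound 3 and compound 4 can be read in this assay; all four are reported only as limits. The compounds shown leave open whether any group on the sulfonyl sulfur changes the read-out at all.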